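Ring-to-chain swap on the core nitrogen: expected response

The source may hold more compounds than are shown below. What is called first, only, known or untested is meant among the compounds shown, and "the series" means these compounds.

Compound 1 `C=CCn1c(=O)n([C@H]2CO[C@@H](CO)C2)c2nc(N)nc(O)c21` gives 10% in a functional assay on the whole organism (B cells) with Mus musculus as the target; on this read-out lower numbers stand for smaller maximal responses and higher numbers for larger maximal responses.
Compound 2 `C=CCn1c(=S)n(C2OC(CO)[C@@H](O)C(O)[C@H]2O)c2nc(N)nc(O)c21` gives 5% in this assay.

The two numbers lie within the scatter of one another, so neither compound can be ranked above the other; both maximal responses are small. Compound 3 `C=CCn1c(=O)n(CCCCO)c2nc(N)nc(O)c21` is not yet measured. Relative to compound 1 it carries a group of 5 heavy atoms (4 carbon, 1 oxygen; no ring) in place of a group of 7 heavy atoms (5 carbon, 2 oxygen; one five-membered non-aromatic ring with 1 hetero atom), on an aromatic nitrogen. Among the measured compounds shown here, no single-place step between measured compounds shows how such a swap acts. Given the small response of compound 1 at 10%, the step of no change at the digits printed from compound 1 to compound 3 (within the scatter) is expected to stay within the scatter. Compound 3 is estimated at 10%, between 2% and 30%.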

Compound 3, largest response reached (reported as maximal response), in percent of the reference or control that the assay uses: 12%
For compound 3 the middle estimate is 2 percentage points below the measured one; the measured number falls inside the stated range.
By their numbers in this assay, from the lowest: compounds 2, 1 and 3 (each within the scatter of the next).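

On the aromatic nitrogen, 4-hydroxybutyl in place of the ring-bearing group gives, in this assay, a number 2 percentage points higher from compound 1 to compound 3 (within the scatter). At this position, then, the five-membered non-aromatic ring and its 2 defined stereocentres can be given up without a change beyond the scatter, and the response stays small. No measurement shown offers an explanation for this result. Going by these compounds, whether an amine or a carboxylic acid at the end of the chain, or a longer chain, on this nitrogen would move the response beyond the scatter remains open.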